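The compounds below may be only part of what the source reports. "The series", "measured", "known", "first", "only" and "open" are said of these compounds alone.

Measured compounds:
compound 1 `C=C(Br)C(=O)Nc1cccc(/C=C2\SC(=O)N(Cc3ccc(C)cc3)C2=O)c1`, 1200 nM
compound 2 `Nc1ccc(/C=C2\SC(=O)N(Cc3ccccc3)C2=O)cc1`, 46000 nM
compound 3 `C=C(Br)C(=O)Nc1ccc(/C=C2\SC(=O)N(Cc3ccccc3)C2=O)cc1`, 1000 nM

In a functional assay on HeLa cells (Homo sapiens) for cytotoxicity, read by cell counting, with a stated time of 4 days (on this read-out lower numbers stand for stronger inhibition and higher numbers for weaker inhibition), compound 3 gives the lowest number of the three. Compound 1 sits within the scatter of it, so the two cannot be ordered; compound 2 lies well beyond the scatter from both.

The one shown step with a single change, a 46-fold lower number from compound 2 to compound 3 (1.66 log units; beyond the scatter), concerns the (1-bromoethenyl)carbonyl on the anilide nitrogen, a part of the molecule that compound 4 `C=C(Br)C(=O)Nc1ccc(/C=C2\SC(=O)N(Cc3ccc(C(F)(F)F)cc3)C2=O)cc1` keeps unchanged. Compound 4 differs from compound 3 in trifluoromethyl in place of hydrogen on an aromatic carbon. For the measured compounds named here, no measured pair probes a substituent on the benzyl ring alone: compound 1 and compound 3 differ in two places at once, and their values fall within the scatter of each other, which hints that a small group on that ring may matter little. The change is therefore expected to give no change at the digits printed from compound 3 to compound 4 (within the scatter), no step beyond the scatter in either direction, with compound 4 estimated at 1000 nM (range 400 nM to 2500 nM).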

Compound 4, half-maximal inhibitory concentration: 13000 nM
Beside the measured number, compound 4's estimate is 13-fold (1.11 log units) below it; measured number outside the range, above it.
By their numbers in this assay, from the lowest: compounds 3 and 1 (each within the scatter of the next); then compound 4; then compound 2.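

In this assay the benzyl ring is not a silent position: the first single change measured there, trifluoromethyl in place of hydrogen on the aromatic carbon para to a large group, gives a 13-fold higher number from compound 3 to compound 4 (1.11 log units; beyond the scatter). Keeping the (1-bromoethenyl)carbonyl on the anilide nitrogen therefore does not by itself hold the number near that of compound 3, and the substituent on this ring has to be counted as a second determinant of the read-out. No measurement at hand bears on the cause of this step.

As far as these compounds go, whether the rise belongs to trifluoromethyl itself or to any group at this carbon stays open; a fluorine, a methoxy or an amine in the same place would separate the two. Also open, from the compounds shown here alone, is whether trifluoromethyl acts alike with the anilide group placed as in compound 1.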